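The source may hold more compounds than are shown below. What is called first, only, known or untested is meant among the compounds shown, and "the series" means these compounds.

Measured so far, in an ADME assay on microsomes from liver (Homo sapiens) for metabolic stability, using NADPH, with a stated time of 60 min, in the presence of a further agent that is not named here; a higher number here means faster removal of the compound, a lower number slower removal:

- Compound 1 `O=C(O)CNC(=O)COc1ccc([C@H]2CC[C@]3(CC2)OOC2(O3)C3CC4CC(C3)CC2C4)cc1`: < 7 mL.min-1.g-1
- Compound 2 `CC(C)(Oc1ccc([C@H]2CC[C@]3(CC2)OOC2(O3)C3CC4CC(C3)CC2C4)cc1)C(=O)O`: < 7 mL.min-1.g-1

Both entries are limits of the assay, not numbers. Compound 2 therefore has no exact place on the scale, and it shares (the limit of < 7 mL.min-1.g-1 in this assay, at which 2 of the 2 values shown sit).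

Compound 3 `CS(=O)(=O)NC(=O)COc1ccc([C@H]2CC[C@]3(CC2)OOC2(O3)C3CC4CC(C3)CC2C4)cc1` has not yet been measured. It carries ((methylsulfonyl)carbamoyl)methyl in place of 1-carboxy-1-methylethyl on an oxygen on an aromatic ring.

Within the data shown here, the only measured step that bears on this change is a step that the two limits leave unreadable from compound 1 to compound 2, so it offers no size to carry over. As the closest guide, compound 1 also has a carbamoyl-containing group at that place and gives the limit < 7 mL.min-1.g-1. On that basis, no change beyond the usual scatter is expected in this assay.

The estimated step is a step that the limit leaves unreadable from compound 2 to compound 3.

For compound 3 the expected value is 6 mL.min-1.g-1, with an estimated range of 3 mL.min-1.g-1 to 15 mL.min-1.g-1.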

Compound 3, intrinsic clearance in microsomes in the Homo sapiens assay: < 7 mL.min-1.g-1
Compound 3: a limit, no number (the forecaster's own chance of this, stated with the estimate: 70%); the middle value is on the limit's open side.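

Compound 1, compound 2 and compound 3 all give a limit, not a number, in the Homo sapiens assay, so no step among them can be read: the limit of < 7 mL.min-1.g-1 in the Homo sapiens assay, at which 3 of the 3 values shown sit.

In a physicochemical assay for solubility, read by nephelometry, in phosphate buffer, measured as kinetic solubility, with a stated time of 30 min, at pH 6.5 (on this read-out higher numbers stand for higher solubility and lower numbers for lower solubility), compound 2 gives < 1.6 ug/mL, which is a limit, not a number. In the physicochemical assay compound 3 gives < 1.6 ug/mL, which is also a limit, not a number.

Compound 2 and compound 3 thus give only a limit in the physicochemical assay, so no step can be read there either: the limit of < 1.6 ug/mL in the physicochemical assay, at which 2 of the 2 values shown sit.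

From the compounds shown here alone, how far apart these compounds truly lie remains open.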